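The compounds below may be only part of what the source reports. "The series", "measured", "known", "first", "only" and "open" are said of these compounds alone.

Measured so far:
- compound 1, `NS(=O)(=O)CC(=O)NCCSc1nonc1/C(=N/O)Nc1ccc(F)c(C(F)F)c1`: 1.07 h
- compound 2, `CC1(C(=O)NCCSc2nonc2/C(=N/O)Nc2ccc(F)c(C(F)F)c2)CCN1`: 0.268 h

In an ADME assay on microsomes from liver (Mus musculus) for metabolic stability (a higher number here means that the compound lasts longer, a lower number that the compound disappears faster), compound 1 gives 1.07 h. Within the data shown here, compound 2 gives 0.268 h in this assay and stands as the lowest of the two numbers; its nearest neighbour is compound 1, and the only step measured is a 4.0-fold lower number from compound 1 to compound 2 (0.60 log units; beyond the scatter).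

Compound 3, `O=C(NCCSc1nonc1/C(=N/O)Nc1ccc(F)c(C(F)F)c1)C1CS(=O)(=O)C1`, differs from compound 2 by a group of 6 heavy atoms (3 carbon, 2 oxygen, 1 sulfur; one four-membered non-aromatic ring with 1 hetero atom) in place of a group of 5 heavy atoms (4 carbon, 1 nitrogen; one four-membered non-aromatic ring with 1 hetero atom), on a carbonyl carbon. The group that enters carries a sulfur with two oxygens, as did the group that left in the step from compound 1 to compound 2, while the group that leaves is the same four-membered ring with nitrogen that entered there. Among the measured compounds shown here, that one measured step is therefore the only guide, and it points back toward the number of compound 1. The expectation is a rise for compound 3 in this assay, of roughly a 2.4-fold higher number from compound 2 to compound 3 (0.38 log units; beyond the scatter), though the ring that enters is not the open chain of compound 1, so the full return is not assumed. For compound 3 the estimate is 0.65 h, expected within 0.3 h to 1.5 h.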

Compound 3, half-life: 0.245 h
Compound 3: middle estimate off by 2.7-fold (0.42 log units), on the high side, outside the stated range (below it).
By their numbers in this assay, from the lowest: compounds 3 and 2 (each within the scatter of the next); then compound 1.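

In this assay, replacing the four-membered ring with nitrogen on the carbonyl carbon by the four-membered ring with sulfur and two oxygens gives a 1.1-fold lower number from compound 2 to compound 3 (0.04 log units; within the scatter), so at this position these two rings cannot be told apart. Compound 3 carries a sulfur with two oxygens, as compound 1 does, yet the change from the open group gives a 4.4-fold lower number from compound 1 to compound 3 (0.64 log units; beyond the scatter), so the presence of that sulfur with its two oxygens does not by itself go with the longer half-life of compound 1. Nothing at hand accounts for either step.

Still open, from the compounds shown here alone, is whether the ring or the nitrogen of the open group separates compound 1 from compound 3. An open methylsulfonylmethyl group on the same carbonyl carbon would bear on that question.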